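The compounds below may be only part of what the source reports. "The series", "measured", "known", "first", "only" and "open" are said of these compounds alone.

Working notes on the series. Compound 1 `CCC(CC)O[C@@H]1C=C(C(=O)O)C[C@H](NC(C)=N)[C@H]1NC(C)=O` and compound 2 `CCOC(=O)C1=C[C@@H](OC(CC)CC)[C@H](NC(C)=O)[C@@H](N/C(C)=N/O)C1` are the measured members. Among the compounds with values here, in a physicochemical assay for solubility, read by HPLC, in phosphate buffer, with a stated time of 20 min, at pH 7.4 (a higher number here means a more soluble compound, a lower number a less soluble compound), compound 2 gives 23000000 nM, the only number in hand. For compound 1 this assay reports a limit, not a number, namely > 50000000 nM. Between the two, then, compound 2 stands as the sole quantified point, the other resting at the limit of > 50000000 nM in this assay, at which 1 of the 2 values shown sits. Compound 3 `CCOC(=O)C1=C[C@@H](OC(CC)CC)[C@H](NC(C)=O)[C@@H](NC(=N)N)C1` differs from compound 2 in a group of 3 heavy atoms (1 carbon, 2 nitrogen; no ring) in place of a group of 4 heavy atoms (2 carbon, 1 nitrogen, 1 oxygen; no ring), on an amine nitrogen. Within the data shown here, no measured step in this assay covers a change of this kind, so the expectation rests only on the two values in hand. The step from compound 2 to compound 3 in this assay is expected to be a 1.7-fold higher number from compound 2 to compound 3 (0.24 log units; within the scatter), a rise that may or may not pass beyond the scatter. Compound 3 is estimated at 40000000 nM, with a range from 15000000 nM to 90000000 nM, and a fair chance that the assay returns only a limit.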

Compound 3, solubility: > 50000000 nM
Compound 3 was reported as a limit; the forecaster's own chance of this, stated with the estimate: 35%; middle value at least 1.2-fold (0.09 log units) away from the limit.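

In this assay, within the data shown here, the group of 3 heavy atoms (1 carbon, 2 nitrogen; no ring) in place of the group of 4 heavy atoms (2 carbon, 1 nitrogen, 1 oxygen; no ring), on an amine nitrogen, gives the first step that can be read: an at least 2.1-fold higher number from compound 2 to compound 3 (0.33 log units; beyond the scatter). This shows that the position is not silent to this change, since the step lies beyond the scatter. The step is bounded on one side only, and compound 2 remains the sole quantified point: the limit of > 50000000 nM in this assay, at which 2 of the 3 values shown sit.

Going by these compounds, how far the step runs past that bound stays open, as does any ordering of compound 3 against compound 1. Also open, on these data alone, is whether a plain amine or a longer chain on this nitrogen would give a number rather than a limit.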